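Aryl methyl to methoxy on the benzyl-amine member

The compounds below may be only part of what the source reports. "The series", "measured", "known", "first", "only" and "open" are said of these compounds alone.

The series shares one core carrying a 4-methylphenyl group; the amine nitrogen bears a methyl in compound 1 `CO[C@@]12CCN(C)C[C@H]1[C@H](c1ccc(C)cc1)C(C#N)=C(N)O2`, a propyl in compound 2 `CCCN1CC[C@@]2(OC)OC(N)=C(C#N)[C@@H](c3ccc(C)cc3)[C@@H]2C1` and a benzyl in compound 3 `CO[C@@]12CCN(Cc3ccccc3)C[C@H]1[C@H](c1ccc(C)cc1)C(C#N)=C(N)O2`. In a functional assay on trachea (Cavia porcellus) (on this read-out lower numbers stand for stronger inhibition and higher numbers for weaker inhibition), compound 1 gives 13200 nM, compound 2 gives 21000 nM and compound 3 gives 27100 nM. Compound 3 stands highest of the three numbers: the step of a 1.3-fold higher number from compound 2 to compound 3 (0.11 log units; within the scatter), whereas the step of a 2.1-fold higher number from compound 1 to compound 3 (0.31 log units; beyond the scatter).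

Compound 4 `COc1ccc([C@@H]2C(C#N)=C(N)O[C@]3(OC)CCN(Cc4ccccc4)C[C@@H]23)cc1` differs from compound 3 by methoxy in place of methyl on an aromatic carbon of a six-membered aromatic ring of carbon only, para to a large group, so that 4-methylphenyl becomes 4-methoxyphenyl. Going by the values given here, no measured step touches this position; a 1.6-fold higher number from compound 1 to compound 2 (0.20 log units; within the scatter) and the two other steps all concern the substituent on the amine nitrogen, so nothing measured bears on the aryl change. No step beyond the scatter is therefore expected in this assay in either direction. The estimate for compound 4 in this assay is 25000 nM, within 8000 nM to 80000 nM. The expected step of a 1.1-fold lower number from compound 3 to compound 4 (0.04 log units; within the scatter) is thus held within the scatter, with a wide range.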

Compound 4, half-maximal inhibitory concentration: 23100 nM
The estimate for compound 4 lay 1.1-fold (0.03 log units) above the measured number; measured number inside the range.
By their numbers in this assay, from the lowest: compounds 1, 2, 4 and 3 (each within the scatter of the next, the first and the last beyond it).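

Going by these compounds alone, this is the first reading at the aryl position. In this assay, 4-methylphenyl and 4-methoxyphenyl on the benzyl-amine member cannot be told apart (a 1.2-fold lower number from compound 3 to compound 4 (0.07 log units; within the scatter)). Here a methoxy with one hydrogen-bond acceptor, on an aromatic carbon para to a large group, takes the place of a methyl with none, and this leaves the read-out within the scatter. Nothing at hand gives a reason for this result.

This single step, on the benzyl-amine member alone, leaves open whether the same exchange would stay within the scatter on the methyl- or propyl-amine members. It also leaves open whether a chlorine, a hydroxyl, a dimethylamino group or a carboxylic acid at the same place would give a number distinct from those of compound 3 and compound 4.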